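The source may hold more compounds than are shown below. What is called first, only, known or untested is meant among the compounds shown, and "the series" means these compounds.

In a physicochemical assay for lipophilicity (a higher number here means a more lipophilic compound, a lower number a more polar compound), three compounds from this series have been measured. Compound 1 `CCCCCCCCNC(=O)Oc1ccc(Cl)cc1C(=O)Nc1cccc(Cl)c1` gives 6.36, and compound 2 `CCCCCCCCCCNC(=O)Oc1ccc(Cl)cc1C(=O)Nc1cccc(Cl)c1` gives 7.19. The two differ only by ethyl in place of hydrogen on a saturated chain carbon, eight bonds along the chain from an amide-type nitrogen, and that change made the step of a number 0.83 log units higher from compound 1 to compound 2 (beyond the scatter). Compound 3 `CCNC(=O)Oc1ccc(Cl)cc1C(=O)Nc1ccc(Cl)cc1` stands lowest of the three: in this assay compound 3 gives 3.79, which lies well below compound 1 and further still below compound 2. How the core of compound 3 differs from the core of compound 1 is not broken down here.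

Compound 4 `CCCCNC(=O)Oc1ccc(Cl)cc1C(=O)Nc1ccc(Cl)cc1` has not yet been measured. It differs from compound 3 by ethyl in place of hydrogen on a saturated chain carbon, two bonds along the chain from an amide-type nitrogen. For the measured compounds named here, this is the same kind of change as the one from compound 1 to compound 2, though the place is not identical: there the ethyl enters eight bonds along the chain from an amide-type nitrogen, here two bonds along the chain from an amide-type nitrogen. A step of about a number 0.85 log units higher from compound 3 to compound 4 (beyond the scatter) is expected. That expectation rests on the earlier step of a number 0.83 log units higher from compound 1 to compound 2 (beyond the scatter). Compound 4 is therefore estimated at 4.64, most likely between 4.2 and 5.1.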

Compound 4, partition coefficient: 4.69
Compound 4: middle estimate off by 0.05 log units, on the low side, and the stated range covers the measured number.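

In this assay, ethyl in place of hydrogen on a saturated chain carbon, two bonds along the chain from an amide-type nitrogen, gave a number 0.90 log units higher from compound 3 to compound 4 (beyond the scatter), close in size to a number 0.83 log units higher from compound 1 to compound 2 (beyond the scatter), so the change carried over from the core of compound 1 to the core of compound 3 with much the same size in these two cases. For the compounds shown here, this rests on only two pairs, which differ in the place of the change as well as in the core, so it does not show that the step would stay the same on other cores or that core and place have no effect of their own. Nothing given here explains the size of either step.

The compounds shown leave open whether an amine, a carboxylic acid or a longer chain in place of the ethyl would give a step of like size. They also leave open whether the same ethyl change, made at the same place on both cores, would give matching steps.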